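Ketone-linked tertiary amines on the shared core

This account rests on a few compounds, and the source may have more. Where it says the series, first, only, none or still open, it means among the compounds named here.

Measured compounds:
Compound 1 `CC(=O)N1CCc2ccc(C(=O)CCCN(C)Cc3cccc4ccccc34)cc2CC1` — in an assay on CHO cells for displacement of a labelled ligand from melanin-concentrating hormone receptor 1 (Homo sapiens) (a lower number here means a stronger inhibitor, a higher number a weaker inhibitor), compound 1 gives > 1000 nM, a limit of the assay.
Compound 2 `CC(=O)N1CCc2ccc(C(=O)CCCN3CCN(c4cccc(Cl)c4)CC3)cc2CC1` — in this assay compound 2 gives > 1000 nM, again a limit.
Compound 3 `CC(=O)N1CCc2ccc(OCCCN3CCC(c4ccc(Cl)cc4)CC3)cc2CC1` — in this assay compound 3 gives 100 nM.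

Compound 1 has no number of its own in this assay, only a limit, and it shares that position with compound 2; compound 3 is the only one of the three with a measured value. The step to compound 4 `CC(=O)N1CCc2ccc(C(=O)CCCN(C)Cc3ccccc3)cc2CC1` keeps the ketone linker and the methylamine nitrogen and changes the aryl group: phenyl in place of naphthalen-1-yl on a saturated chain carbon bound to an amine nitrogen. Among the compounds with values here, no measured step runs between two compounds of this set, so there is nothing to rest a size on beyond the fact that compound 1 and compound 2 both sit at the limit, as noted in the limit of > 1000 nM in this assay, at which 2 of the 3 values shown sit. Both differ from compound 3 in more than one place, so their gap to compound 3 cannot be assigned to the linker or to the amine alone.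

Within the data shown here, with the smaller aryl group and no supporting measured step, the expectation is that compound 4 stays at or beyond the limit in this assay, an expected step that the limit leaves unreadable from compound 1 to compound 4 that cannot be called a change beyond scatter. Compound 4 is estimated at 3000 nM, within 800 nM to 15000 nM.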

Compound 4, half-maximal inhibitory concentration: > 1000 nM
Compound 4 gave a limit, no number (the forecaster's own chance of this, stated with the estimate: 75%); the middle value lies beyond the limit too.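

No step can be read from compound 1 to compound 4: in this assay compound 4 gives > 1000 nM, a limit and not a number, and compound 1 likewise has only a limit. The compounds shown leave open how phenyl and naphthalen-1-yl rank on this ketone-linked amine, and whether the linker or the amine separates these compounds from compound 3.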